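This account rests on a few compounds, and the source may have more. Where it says the series, first, only, none or still open, it means among the compounds named here.

Compound 1 `Cc1cc(C)c2ccc(=O)n(CCN(C)C)c2n1` is the starting point. In an assay on isolated protein (strain Charles River) for antagonist activity at histamine H2 receptor (Rattus norvegicus) (a lower number here means that less compound is needed, a higher number that more compound is needed for the effect), compound 1 gives 3.93 ug/mL, the second highest of the three numbers measured: compound 2 `Cc1cc(C(F)(F)F)nc2c1ccc(=O)n2CCN(C)C` gives 1.6 ug/mL, and compound 3 `Cc1cc(Cl)nc2c1ccc(=O)n2CCN(C)C` gives 9.23 ug/mL. The move to compound 4 `Cc1nc2c(ccc(=O)n2CCN(C)C)c(C)c1C` is methyl in place of hydrogen on an aromatic carbon, on an aromatic carbon of the shared core, ortho to two methyl groups. For the measured compounds named here, no measured step adds a group where hydrogen stood; the known steps, a 2.5-fold lower number from compound 1 to compound 2 (0.39 log units; beyond the scatter) and a 2.3-fold higher number from compound 1 to compound 3 (0.37 log units; beyond the scatter), swap one group for another at a different carbon, so they bear on this change only loosely. A small step, or none beyond the scatter, is therefore expected in this assay. The estimate for compound 4 is 3.5 ug/mL, with a range from 1.5 ug/mL to 8 ug/mL, meaning an expected 1.1-fold lower number from compound 1 to compound 4 (0.05 log units; within the scatter).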

Compound 4, half-maximal effective concentration: 12.5 ug/mL
Estimate against measurement, compound 4: 3.6-fold (0.55 log units) below, outside the stated range (above it).
By their numbers in this assay, from the lowest: compound 2; then compound 1; then compounds 3 and 4 (each within the scatter of the next).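

In this assay, methyl in place of hydrogen on this aromatic carbon, ortho to two methyl groups, gives a 3.2-fold higher number from compound 1 to compound 4 (0.50 log units; beyond the scatter). This position of the shared core is therefore not indifferent to substitution: adding a single carbon is enough to mean that more compound is needed. Nothing available explains this change. Still open, on these data alone, is whether this higher number holds for other groups at this carbon, such as fluoro, methoxy or ethyl, or whether any group here would lower the number instead.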